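A few compounds are considered here, and "the series" means these few. Any claim that something is new, unique, unknown or untested is made for them only; others in the source may bear on it.

Measured in a functional assay on MCF cells (Homo sapiens) for antiproliferative activity, with a stated time of 72 h; on this read-out higher numbers stand for weaker inhibition and lower numbers for stronger inhibition:
Compound 1 `OC[C@H]1O[C@@H](n2cnc3c(NCc4cccc(F)c4)ncnc32)[C@H](O)[C@@H]1O`: 15300 nM
Compound 2 `OC[C@H]1O[C@@H](n2cnc3c(NCc4cccc(Br)c4)ncnc32)[C@H](O)[C@@H]1O`: > 166000 nM (a limit)

Compound 2 gives no number, and it stands at the limit of > 166000 nM in this assay, at which 1 of the 2 values shown sits. Compound 3 `OC[C@H]1O[C@@H](n2cnc3c(NCc4ccc(Br)cc4)ncnc32)[C@H](O)[C@@H]1O` has the same atoms, joined differently: 4-bromophenyl in place of 3-bromophenyl on a saturated chain carbon bound to a nitrogen on an aromatic ring. This places 4-bromophenyl in place of 3-bromophenyl on a saturated chain carbon bound to a nitrogen on an aromatic ring.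

For the measured compounds named here, only one measured step bears on this change, and only indirectly. That step, an at least 10-fold higher number from compound 1 to compound 2 (1.03 log units; beyond the scatter), is large, but it exchanges fluoro for bromo and leaves the halogen where it was. Going by the values given here, no measured step moves the bromine, so neither its size nor its direction carries over. In this assay, no step beyond the scatter is therefore expected, and another limit is quite possible. The expected change is an at least 1.3-fold lower number from compound 2 to compound 3 (0.14 log units; that floor lies within the scatter). Compound 3 is estimated at 120000 nM, with an expected range of 30000 nM to 300000 nM.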

Compound 3, half-maximal inhibitory concentration: > 166000 nM
Compound 3 gave a limit, no number (the forecaster's own chance of this, stated with the estimate: 55%); middle value at least 1.3-fold (0.14 log units) away from the limit.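

In this assay compound 3 gives > 166000 nM as a limit and not a number, so 4-bromophenyl, like 3-bromophenyl, yields no readable value: the limit of > 166000 nM in this assay, at which 2 of the 3 values shown sit. The step from compound 2 to compound 3 cannot be read, the two values being limits. Set against the fluoro compound, the data show an at least 10-fold higher number from compound 1 to compound 3 (1.03 log units; beyond the scatter), so a large step now holds for both bromine placings shown, and compound 1 alone gives a number.

Going by these compounds, whether moving the bromine changes activity at all stays open, any difference being hidden behind the two limits. Also open, on these data alone, is whether a chloro or methoxy group in place of the halogen, or a plain phenyl, would give a readable value in this assay.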